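Dropping the thiazolyl ring from a benzimidazole sulfonylcarbamate

The source may report more compounds than this note shows. Statements on the series, on what has been measured and on what is new or still open speak of the compounds shown alone.

Measured compounds:
- Compound 1 `CCCCOC(=O)NS(=O)(=O)c1ccc(CCC)cc1-c1ccc(Cn2c(-c3nccs3)nc3ccccc32)cc1`: 0.35 h
- Compound 2 `CCCc1ccc(S(=O)(=O)NC(=O)OCCCC(F)(F)F)c(-c2ccc(Cn3c(C(C)(C)C)nc4ccccc43)cc2)c1`: 0.333 h

Of the compounds shown here, two from this study have been tested in an ADME assay on microsomes from liver (Homo sapiens) for metabolic stability, read by LC-MS, using NADPH, with stated times of 5 min and 60 min, tested at 1 uM; a higher number here means that the compound lasts longer, a lower number that the compound disappears faster. In this assay compound 1 gives 0.35 h, and compound 2 gives 0.333 h. The two numbers lie within the usual scatter of each other, so neither compound can be called the more stable of the two; compound 1 is simply the starting point for the step considered here. Among the compounds with values here, no pair of measured compounds differs in a single place, so there is no measured step on which to lean.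

Compound 3 `CCCCOC(=O)NS(=O)(=O)c1ccc(CCC)cc1-c1ccc(Cn2cnc3ccccc32)cc1` has not yet been measured in this assay. It differs from compound 1 in one place: hydrogen in place of 1,3-thiazol-2-yl on an aromatic carbon. Compound 2, which carries a different group at the same place, sits close to compound 1, which gives little reason to expect a large shift from that change. Compound 3 is therefore expected to give 0.3 h, with a range from 0.12 h to 0.7 h; the estimated step of a 1.2-fold lower number from compound 1 to compound 3 (0.07 log units; within the scatter) is expected to lie within the scatter.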

Compound 3, half-life: 0.167 h
Compound 3: middle estimate off by 1.8-fold (0.25 log units), on the high side; the range from low to high includes it.
By their numbers in this assay, from the lowest: compounds 3, 2 and 1 (each within the scatter of the next, the first and the last beyond it).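

Hydrogen in place of 1,3-thiazol-2-yl gives a 2.1-fold lower number from compound 1 to compound 3 (0.32 log units; beyond the scatter) in this assay, the first measured change in this series that touches a single place. Within the data shown here, the earlier compounds offered no such step, so this is the first sign that the group on this aromatic carbon, between two ring nitrogen atoms and next to the ring atom that bears a large group, has a bearing on the half-life, although the step is modest. Nothing available here explains why the half-life follows this change.

The compounds shown leave open whether the 1,3-thiazol-2-yl ring itself matters or whether almost any group at this place would keep the half-life of compound 1, a question that a small methyl group, a phenyl ring or an oxazole ring at the same carbon could help to settle. They also leave open whether the same step would appear on the core of compound 1 with a different chain elsewhere in the molecule, since a single pair cannot show how far this change carries.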